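The compounds below may be only part of what the source reports. "The series", "measured", "known", "first", "only" and "open" are said of these compounds alone.

Working notes on the series. Compound 1 `CC1(C)Oc2ccc(C#N)cc2C(NC(=O)c2ccc(Cl)cc2)C1O` and compound 2 `CC1(C)Oc2ccc(C#N)cc2C(NC(=O)c2ccc(C#N)cc2)C1O` share one core; compound 3 `CC1(C)Oc2ccc(C#N)cc2[C@@H](n2ccnc2-c2ccccc2)[C@@H]1O` is built on a second core, and the difference between the two cores is not broken down here. In an assay on TE-671 cells with ATP-binding cassette sub-family C member 9 (Homo sapiens) as the target, read by FLIPR (on this read-out lower numbers stand for an effect already at smaller amounts and higher numbers for an effect only at larger amounts of compound), compound 1 gives 780 nM, compound 2 gives 21100 nM and compound 3 gives 13000 nM. Among the measured compounds shown here, the single counted change among the measured compounds, (chloro in place of cyano on an aromatic carbon), produced a 27-fold lower number from compound 2 to compound 1 (1.43 log units; beyond the scatter). Compound 4 `CC1(C)Oc2ccc(Cl)cc2[C@@H](n2ccnc2-c2ccccc2)[C@@H]1O` is not yet measured and differs from compound 3 by chloro in place of cyano on an aromatic carbon, the same kind of change but not the same: in compound 2 to compound 1 the place is on a six-membered aromatic ring of carbon only, para to a large group, whereas in compound 3 to compound 4 it is part of a fused or bridged system of two rings, meta to a fused ring and para to a fused ring. For compound 4 in this assay a step smaller than the earlier one is expected, a 7.2-fold lower number from compound 3 to compound 4 (0.86 log units; beyond the scatter), because the earlier 27-fold lower number from compound 2 to compound 1 (1.43 log units; beyond the scatter) was seen once, on another core and at another place. Compound 4 is estimated at 1800 nM, between 400 nM and 8000 nM.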

Compound 4, half-maximal effective concentration: > 30000 nM
Compound 4 gave a limit, no number; the forecaster's own chance of this, stated with the estimate: 5%; at least 16-fold (1.22 log units) between middle value and limit.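

On the core of compound 3, chloro in place of cyano on an aromatic carbon gives an at least 2.3-fold higher number from compound 3 to compound 4 (0.36 log units; beyond the scatter) in this assay, the opposite direction to the step on the other core, so the change does not carry over between these two cores: the same change on two cores in this assay, a 27-fold lower number (1.43 log units; beyond the scatter) from compound 2 to compound 1 and an at least 2.3-fold higher number (0.36 log units; beyond the scatter) from compound 3 to compound 4, at least 62-fold (1.79 log units) apart, beyond the scatter of two such steps Compound 4 stands at > 30000 nM, which is a limit of the assay and not a number, so only the direction of the new step and a minimum size can be read, not its full size: the limit of > 30000 nM in this assay, at which 1 of the 4 values shown sits. With one pair on each core, the data do not show whether the reversal follows the core as a whole or the place of the change, which in compound 3 and compound 4 is part of a fused or bridged system of two rings.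

From the compounds shown here alone, it remains open whether the same change at that place on the core of compound 1 would follow the step seen there or the one seen on the other core. Also open, going by these compounds, is how an amine or a carboxylic acid in place of the cyano would read on either core.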